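A few compounds are considered here, and "the series" means these few. Any claim that something is new, unique, unknown or untested is made for them only; others in the source may bear on it.

Compounds measured in an assay on Prostate gland for inhibition of steroid 5-alpha-reductase (Rattus norvegicus); a lower number here means a stronger inhibitor, a higher number a weaker inhibitor:

compound 1 `C/C(=C\C(=O)Nc1ccccc1OCCCC(=O)O)c1ccc2c(ccn2C)c1` gives 780 nM
compound 2 `CCCn1ccc2cc(/C(C)=C/C(=O)Nc3ccccc3OCCCC(=O)O)ccc21` gives 190 nM
compound 3 `CCCCC(C)n1ccc2cc(/C(C)=C/C(=O)Nc3ccccc3OCCCC(=O)O)ccc21` gives 6 nM

Compound 3 stands lowest of the three numbers in this assay; the nearest of the others is compound 2, the furthest compound 1, and both gaps are beyond the scatter. All three share the same core and differ only in the group on the aromatic nitrogen. The steps along that group are a 4.1-fold lower number from compound 1 to compound 2 (0.61 log units; beyond the scatter), a 32-fold lower number from compound 2 to compound 3 (1.50 log units; beyond the scatter) and, across the whole range, a 130-fold lower number from compound 1 to compound 3 (2.11 log units; beyond the scatter), so each growth of that group so far has brought a lower number.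

Compound 4 `C/C(=C\C(=O)Nc1ccccc1OCCCC(=O)O)c1ccc2c(ccn2Cc2ccc(C)cc2)c1` is not yet measured. Its change from compound 3 is 4-methylbenzyl in place of 1-methylpentyl on an aromatic nitrogen. For the measured compounds named here, no measured step involves a group with a ring on that nitrogen, so the three steps bear on it only in that the group stays large rather than returning to methyl or propyl. The expectation is therefore a number near that of compound 3, and not a return towards compound 1 or compound 2. For compound 4 in this assay the estimate is 15 nM, with a range from 3 nM to 80 nM. The step this estimate means, a 2.5-fold higher number from compound 3 to compound 4 (0.40 log units; beyond the scatter), is expected to stay within or only slightly beyond the scatter.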

Compound 4, half-maximal inhibitory concentration: 88 nM
Compound 4: middle estimate off by 5.9-fold (0.77 log units), on the low side; the whole stated range lies below it.
By their numbers in this assay, from the lowest: compound 3; then compound 4; then compound 2; then compound 1.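

In this assay, the number does not simply fall as the group on the aromatic nitrogen grows: 4-methylbenzyl holds more heavy atoms than 1-methylpentyl, yet the exchange gives a 15-fold higher number from compound 3 to compound 4 (1.17 log units; beyond the scatter) and so compound 4 goes against the trend seen through compound 3. The ring-bearing group still compares well with the two smaller groups, with a 2.2-fold lower number from compound 2 to compound 4 (0.33 log units; beyond the scatter) and an 8.9-fold lower number from compound 1 to compound 4 (0.95 log units; beyond the scatter), so a large group containing one six-membered aromatic ring keeps part of the gain but does not match 1-methylpentyl. No measured evidence bears on why the two large groups differ so widely in this series.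

The four compounds leave open whether the low number of compound 3 depends on the branch in 1-methylpentyl or on chain length, which an unbranched hexyl group on the same nitrogen would separate, and whether cyclohexylmethyl would behave like the open chain or like the aromatic ring. They also leave open what the methyl of 4-methylbenzyl contributes, since plain benzyl is absent from the compounds shown here.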